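Trimming the ring-nitrogen benzyl to methyl in a thiophene amide series

This account rests on a few compounds, and the source may have more. Where it says the series, first, only, none or still open, it means among the compounds named here.

Compound 3 `Nc1sc2c(c1C(=O)NNc1ccccc1)CCN(Cc1ccccc1)C2` gives 7800 nM in an in vitro assay on CHOk1 cells with adenosine receptor A1 (Homo sapiens) as the target (a lower number here means that less compound is needed, a higher number that more compound is needed for the effect), the lowest of the two numbers at hand, with compound 2 `NNC(=O)c1c(N)sc2c1CCN(Cc1ccccc1)C2` at 8900 nM within the scatter of it. Compound 1 `Nc1sc2c(c1C(=O)NCc1cccc(Cl)c1)CCN(Cc1ccccc1)C2` reaches only the assay limit of > 20000 nM in this assay, an observation recorded as the limit of > 20000 nM in this assay, at which 1 of the 3 values shown sits. The measured steps of an at least 2.2-fold lower number from compound 1 to compound 2 (0.35 log units; beyond the scatter), an at least 2.5-fold lower number from compound 1 to compound 3 (0.40 log units; beyond the scatter) and a 1.1-fold lower number from compound 2 to compound 3 (0.06 log units; within the scatter) all alter the amide-type nitrogen and leave the ring amine untouched. Compound 4 `CN1CCc2c(sc(N)c2C(=O)NNc2ccccc2)C1` instead changes that ring amine: hydrogen in place of phenyl on a saturated chain carbon bound to an amine nitrogen in a ring. Among the compounds with values here, no measured step bears on this change, so compound 4 is expected to show a step of a 1.3-fold higher number from compound 3 to compound 4 (0.11 log units; within the scatter), with no direction that can be anticipated beyond the scatter. Compound 4 is estimated at 10000 nM, between 3000 nM and 30000 nM.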

Compound 4, half-maximal effective concentration: 11500 nM
Compound 4: the middle estimate sits 1.2-fold (0.06 log units) below what was measured; low and high end bracket the measured number.
By their numbers in this assay, from the lowest: compounds 3, 2 and 4 (each within the scatter of the next). At a limit, above all of these: compound 1.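

In this assay, within the data shown here, replacing benzyl with methyl on the ring nitrogen gives a 1.5-fold higher number from compound 3 to compound 4 (0.17 log units; within the scatter), the first measured step at this position, which the earlier steps left untouched. The benzyl group can therefore give way to methyl in this anilino amide without a shift beyond the scatter. No available measurement bears on the reason for this result.

From the compounds shown here alone, whether a longer chain, a carboxylic acid or a free amine hydrogen on the ring nitrogen would give a step beyond the scatter remains open. So does whether the same exchange would behave alike with the 3-chlorobenzyl amide of compound 1.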